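The source may report more compounds than this note shows. Statements on the series, on what has been measured and on what is new or still open speak of the compounds shown alone.

Within the data shown here, compound 2 `CC[C@]1(O)[C@H](O)C[C@H](c2ccncc2NC(=O)c2nc(-c3ncccc3F)ccc2N)C[C@@H]1C` reads 133 mL/min/kg in an ADME assay on microsomes from liver (Rattus norvegicus) for metabolic stability, read by LC-MS, using NADPH, with a stated time of 30 min, tested at 1 uM (on this read-out lower numbers stand for slow clearance and higher numbers for fast clearance), and holds the higher of the two numbers so far; compound 1 `C[C@H]1C[C@@H](c2ccncc2NC(=O)c2nc(-c3ncccc3F)ccc2N)C[C@@H](O)[C@@]1(O)CF` reads 41 mL/min/kg in the same test, a gap beyond the scatter. Compound 3 `C[C@H]1C[C@@H](c2ccncc2NC(=O)c2nc(-c3ncccc3F)ccc2N)C[C@@H](O)[C@]1(C)O` differs from compound 2 by hydrogen in place of methyl on a saturated chain carbon bound to a saturated ring carbon (hydrogen in place of methyl on a saturated chain carbon bound to a saturated ring carbon, so that ethyl becomes methyl). Among the measured compounds shown here, only one measured step bears on this change: a 3.2-fold higher number from compound 1 to compound 2 (0.51 log units; beyond the scatter) (modest), with methyl in place of fluoro. For the measured compounds named here, on that single step, a modest move to a lower number is expected in this assay for compound 3, although no measured compound carries methyl there. The expected step is a 1.8-fold lower number from compound 2 to compound 3 (0.25 log units; within the scatter) and remains tentative. Compound 3 is estimated at 75 mL/min/kg with an expected range from 38 mL/min/kg to 135 mL/min/kg in this test.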

Compound 3, clearance: 35 mL/min/kg
Estimate against measurement, compound 3: 2.1-fold (0.33 log units) above; measured number below the stated range.
By their numbers in this assay, from the lowest: compounds 3 and 1 (each within the scatter of the next); then compound 2.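

Replacing ethyl with methyl in this assay gives a 3.8-fold lower number from compound 2 to compound 3 (0.58 log units; beyond the scatter), so shortening the chain by this one carbon changes the read-out by more than the scatter. Hydrogen in place of fluoro on the same saturated chain carbon gives a 1.2-fold lower number from compound 1 to compound 3 (0.07 log units; within the scatter), so the fluoro and hydrogen forms are not separated here, and of the three compounds only the ethyl compound, compound 2, stands apart, with the fastest clearance. No measurement at hand explains why ethyl differs from the other two.

Going by these compounds, how a longer chain such as propyl, or an amine at this place, would read remains open. Also open, on these data alone, is whether the same grouping of the three compounds would hold with liver microsomes from another species.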